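The source may hold more compounds than are shown below. What is called first, only, known or untested is meant among the compounds shown, and "the series" means these compounds.

Compound 1 `COc1cc(-c2nn(-c3cccc(NC(=O)c4cccc(C(F)(F)F)c4)c3)cc2-c2ccncc2)ccc1Cl` gives 10800 nM in a functional assay on NCI-H322M cells (Homo sapiens) for inhibition, read by sulforhodamine B assay, with a stated time of 48 h; on this read-out higher numbers stand for weaker inhibition of growth and lower numbers for stronger inhibition of growth.
Compound 2 `COc1cc(-c2nn(-c3cccc(NC(=O)Nc4cccc(C(F)(F)F)c4)c3)cc2-c2ccncc2)ccc1Cl` gives 1210 nM.
Compound 3 `COc1cc(-c2nn(-c3cccc(NC(=O)c4ccc(Cl)c(C(F)(F)F)c4)c3)cc2-c2ccncc2)ccc1Cl` gives 12800 nM.

All three share one core and differ only in the group attached to the carbonyl carbon. Compound 3 shows the highest of the three numbers; the step of a 1.2-fold higher number from compound 1 to compound 3 (0.07 log units; within the scatter) is within the scatter, whereas the step of an 11-fold higher number from compound 2 to compound 3 (1.02 log units; beyond the scatter) is large. Compound 4 `COc1cc(-c2nn(-c3cccc(NC(=O)Nc4ccc(Cl)c(C(F)(F)F)c4)c3)cc2-c2ccncc2)ccc1Cl` is compound 3 with (4-chloro-3-(trifluoromethyl)phenyl)amino in place of 4-chloro-3-(trifluoromethyl)phenyl on a carbonyl carbon. The same kind of change, an amino nitrogen entering on the carbonyl carbon, has been seen once in this assay: an 8.9-fold lower number from compound 1 to compound 2 (0.95 log units; beyond the scatter). A step of similar size and direction is expected here, so compound 4 is estimated to give 1400 nM, with a likely range from 500 nM to 4000 nM. This expectation corresponds to the step of a 9.1-fold lower number from compound 3 to compound 4 (0.96 log units; beyond the scatter).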

Compound 4, concentration for 50% growth inhibition: 1500 nM
For compound 4 the middle estimate is 1.1-fold (0.03 log units) below the measured one; the range from low to high includes it.
By their numbers in this assay, from the lowest: compounds 2 and 4 (each within the scatter of the next); then compounds 1 and 3 (each within the scatter of the next).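

The amino nitrogen on the carbonyl carbon lowers the number again with a second aromatic group attached, an 8.5-fold lower number from compound 3 to compound 4 (0.93 log units; beyond the scatter), so this change is no longer seen on one pair alone. Taking this change and the chloro group together gives a 7.2-fold lower number from compound 1 to compound 4 (0.86 log units; beyond the scatter). With the amino nitrogen present, the chloro group still makes no clear difference, a 1.2-fold higher number from compound 2 to compound 4 (0.09 log units; within the scatter), and the two chloro steps agree: the same change on two cores in this assay, a 1.2-fold higher number (0.07 log units; within the scatter) from compound 1 to compound 3 and a 1.2-fold higher number (0.09 log units; within the scatter) from compound 2 to compound 4, 1.0-fold (0.02 log units) apart, within the scatter of two such steps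

Still open, from the compounds shown here alone, is whether an amine or a carboxylic acid in place of the chloro group would move the number.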